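A few compounds are considered here, and "the series" means these few. Any claim that something is new, unique, unknown or untested is made for them only; others in the source may bear on it.

Measured in a physicochemical assay for lipophilicity, measured as octanol-water partition; on this read-out higher numbers stand for higher lipophilicity and lower numbers for lower lipophilicity:
Compound 1 `CC(C)[C@@H]1CC[C@@H](C)C[C@H]1OC(=O)c1ccc(Br)cc1`: 5.61
Compound 2 `CC(C)[C@@H]1CC[C@@H](C)C[C@H]1OC(=O)c1ccccc1`: 4.82

Of these two compounds, compound 2 stands lowest at 4.82. Compound 3 `CC(C)[C@@H]1CC[C@@H](C)C[C@H]1OC(=O)c1ccc([N+](=O)[O-])cc1` has nitro in place of hydrogen on an aromatic carbon, para to a large group (nitro in place of hydrogen on an aromatic carbon). Among the measured compounds shown here, one measured step bears on this change: a number 0.79 log units lower from compound 1 to compound 2 (beyond the scatter), with hydrogen in place of bromo on the same aromatic carbon. For the measured compounds named here, that step concerns bromo, and no measured step covers nitro. No shift beyond the scatter is expected in this assay, and the direction remains uncertain. The expected change is a number 0.03 log units higher from compound 2 to compound 3 (within the scatter). For compound 3 the estimated value is 4.85, with an expected range of 4.4 to 5.3.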

Compound 3, partition coefficient: 4.78
Beside the measured number, compound 3's estimate is 0.07 log units above it; the measured number falls inside the stated range.
By their numbers in this assay, from the lowest: compounds 3 and 2 (each within the scatter of the next); then compound 1.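

On the aromatic carbon para to a large group, nitro and hydrogen are not separated in this assay, with a number 0.04 log units lower from compound 2 to compound 3 (within the scatter). Compound 1 differs from both, with a number 0.83 log units lower from compound 1 to compound 3 (beyond the scatter) and the earlier a number 0.79 log units lower from compound 1 to compound 2 (beyond the scatter), so of the three groups at this place only bromo stands apart. Nothing available accounts for these numbers.

On these data alone, whether an amine, a carboxylic acid or a methoxy group here would fall with compound 1 or with compound 2 and compound 3 stays open. So does whether the same steps would hold at another ring carbon.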